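A Second Trifluoromethyl Group on Two Related Cores

A few compounds are considered here, and "the series" means these few. Any claim that something is new, unique, unknown or untested is made for them only; others in the source may bear on it.

Compound 3 `CN(C(=O)NC(=O)c1ccc(F)c(F)c1)c1nc(C(F)(F)F)c(C(=O)N/N=C/c2cccc(C(F)(F)F)c2)s1` and compound 1 `CN(C(=O)NC(=O)c1ccc(F)c(F)c1)c1nc(C(F)(F)F)c(C(=O)N/N=C/c2cc(C(F)(F)F)cc(C(F)(F)F)c2)s1` share one core and differ at a single point: trifluoromethyl in place of hydrogen on an aromatic carbon. In a functional assay on HepG2 cells (Homo sapiens) for inhibition, read by MTT assay, with a stated time of 72 h (a higher number here means a weaker inhibitor, a lower number a stronger inhibitor), compound 3 gives 5.6 ug/mL and compound 1 gives 5.47 ug/mL, so that a 1.0-fold lower number from compound 3 to compound 1 (0.01 log units; within the scatter). Compound 2 `Cc1nc(N(C)C(=O)NC(=O)c2c(F)cccc2F)sc1C(=O)N/N=C/c1cccc(C(F)(F)F)c1` is built on a different core; the difference between the two cores is not broken down here. In this assay compound 2 gives 31.6 ug/mL, the highest of the three numbers, and its gap to both compound 3 and compound 1 lies beyond the scatter. Compound 4 `Cc1nc(N(C)C(=O)NC(=O)c2c(F)cccc2F)sc1C(=O)N/N=C/c1cc(C(F)(F)F)cc(C(F)(F)F)c1` has not yet been measured. It stands to compound 2 as compound 1 stands to compound 3, carrying the same change at a place described in the same words: trifluoromethyl in place of hydrogen on an aromatic carbon. The expectation for compound 4 rests on that earlier pair, because compound 3 at 5.6 ug/mL and compound 1 at 5.47 ug/mL sit within the scatter of one another. Compound 4 is therefore estimated at about 28 ug/mL, with a likely range from 12 ug/mL to 65 ug/mL. The expected step of a 1.1-fold lower number from compound 2 to compound 4 (0.05 log units; within the scatter) is taken to be a small one.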

Compound 4, half-maximal inhibitory concentration: 11.4 ug/mL
Compound 4: the middle estimate sits 2.5-fold (0.39 log units) above what was measured; the whole stated range lies above it.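

In this assay the second trifluoromethyl group on the aromatic ring brings a clear gain on the core of compound 2, with a 2.8-fold lower number from compound 2 to compound 4 (0.44 log units; beyond the scatter). Set beside the earlier pair, the same change did not carry over at the same size from one core to the other: the same change on two cores in this assay, a 1.0-fold lower number (0.01 log units; within the scatter) from compound 3 to compound 1 and a 2.8-fold lower number (0.44 log units; beyond the scatter) from compound 2 to compound 4, 2.7-fold (0.43 log units) apart, beyond the scatter of two such steps. This shows that the effect of the change in this series depends on the core it is made on, but it does not show which of the differences between the two cores is responsible, and one pair on each core gives no rule for any further core.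

The compounds shown leave open whether the core dependence is specific to trifluoromethyl or would also appear with another group in its place, such as a nitrile, a methoxy group or an amine. They also leave open how the step would behave on a core that differs from either of these two in only one place.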